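Series notes: methoxy to hydroxy on the saturated ring

This account rests on a few compounds, and the source may have more. Where it says the series, first, only, none or still open, it means among the compounds named here.

Compound 1 `CNC(=O)c1cc(C(=O)N[C@H]2[C@@H]3C[C@@H](OC)C[C@@H]32)n([C@@H](C)c2ccccc2)n1` gives the highest number of the three measured in an ADME assay for permeability (a higher number here means that the compound crosses the layer faster, a lower number that the compound crosses the layer more slowly), at 440 nm/s. Compound 3 `CCC(=O)c1c[nH]c(C(=O)NC)c1` comes nearest, with 200 nm/s in this assay, a gap beyond the scatter. Compound 2 `CNC(=O)c1cc(C(=O)N[C@H]2CC[C@H](O)CC2)c([C@@H](C)c2cccc(OC)c2)o1` lies furthest away, with 44 nm/s in this assay; compound 2 differs from compound 1 in more than one place, so its two values show only the distance, not a step.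

The next compound, compound 4 `CNC(=O)c1cc(C(=O)N[C@H]2[C@@H]3C[C@@H](O)C[C@@H]32)n([C@@H](C)c2ccccc2)n1`, differs from compound 1 in one place: hydrogen in place of methyl on an oxygen on a saturated carbon. Going by the values given here, no single-change step between measured compounds is available to set the size of this change, so the expectation rests on compound 1 alone and on the general picture given by the three numbers.

A moderate decrease is expected, somewhat beyond the scatter, in this assay from compound 1 to compound 4, of the size a 2.4-fold lower number from compound 1 to compound 4 (0.39 log units; beyond the scatter). Compound 4 is estimated at 180 nm/s in this assay, with a range from 70 nm/s to 400 nm/s.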

Compound 4, apparent permeability in the ADME assay: 61 nm/s
Beside the measured number, compound 4's estimate is 3.0-fold (0.47 log units) above it; measured number outside the range, below it.
By their numbers in the ADME assay, from the lowest: compounds 2 and 4 (each within the scatter of the next); then compound 3; then compound 1.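

Going by these compounds alone, in the ADME assay, methoxy to hydroxy on a saturated carbon now has a measured size on the core of compound 1, with a 7.2-fold lower number from compound 1 to compound 4 (0.86 log units; beyond the scatter), the first single-change step and one that lies beyond the scatter. In a physicochemical assay for solubility (a higher number here means a more soluble compound, a lower number a less soluble compound), compound 1 gives >= 150 ug/mL, which is a limit of the assay and not a number. In the physicochemical assay compound 4 gives >= 291 ug/mL, also a limit and not a number, and the step for this change in that assay cannot be read.

Going by these compounds, a single pair carries this change, and whether the step holds on another core remains open. On these data alone, how an amine or an ethoxy group on the same saturated carbon would read in the ADME assay also remains open.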